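Replacing an imidazole with a cyclopropyl-benzoic acid on the piperidine

This account rests on a few compounds, and the source may have more. Where it says the series, first, only, none or still open, it means among the compounds named here.

Compound 1 `OC[C@@H](O[C@H]1CCCN(Cc2ncc[nH]2)[C@H]1c1ccccc1)c1cc(Cl)cc(Cl)c1`: 47000 nM
Compound 2 `Cc1cc(C(=O)O)ccc1CN1CCC[C@H](OC(c2cc(Cl)cc(Cl)c2)C(C)(C)O)[C@@H]1c1ccccc1`: 17000 nM
Compound 3 `Cc1cc(C(=O)O)ccc1CN1CCC[C@H](O[C@@H](CC(C)(C)O)c2cc(Cl)cc(Cl)c2)[C@@H]1c1ccccc1`: 330 nM

In an assay on isolated protein for activation of cGMP-dependent protein kinase 1 (Homo sapiens), read by ADP-Glo, with stated times of 30 min and 2 h, in the presence of a further agent that is not named here (on this read-out higher numbers stand for an effect only at larger amounts of compound and lower numbers for an effect already at smaller amounts), compound 1 gives 47000 nM, the highest of the three numbers; compound 2 gives 17000 nM and compound 3 gives 330 nM, both beyond the scatter below it. Compound 4 `O=C(O)c1ccc(CN2CCC[C@H](O[C@H](CO)c3cc(Cl)cc(Cl)c3)[C@@H]2c2ccccc2)c(C2CC2)c1` has not been measured. It differs from compound 1 by a group of 12 heavy atoms (10 carbon, 2 oxygen; one three-membered non-aromatic ring of carbon only, one six-membered aromatic ring of carbon only) in place of a group of 5 heavy atoms (3 carbon, 2 nitrogen; one five-membered aromatic ring with 2 hetero atoms), on a saturated chain carbon bound to an amine nitrogen in a ring. Compounds 2 and 3 both carry a benzoic acid on that same carbon and both give lower numbers than compound 1, so compound 4 is expected to move in the same direction, with a step estimated as a 7.8-fold lower number from compound 1 to compound 4 (0.89 log units; beyond the scatter). Compound 4 is therefore expected to give about 6000 nM, within 1000 nM to 30000 nM.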

Compound 4, half-maximal effective concentration: 1800 nM
Beside the measured number, compound 4's estimate is 3.3-fold (0.52 log units) above it; measured number inside the range.
By their numbers in this assay, from the lowest: compound 3; then compound 4; then compound 2; then compound 1.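

In this assay, exchanging the 1H-imidazol-2-yl for the cyclopropyl-benzoic acid gives a 26-fold lower number from compound 1 to compound 4 (1.42 log units; beyond the scatter) on a saturated chain carbon bound to an amine nitrogen in a ring. Within the data shown here, compounds 2 and 3 differ from compound 1 in more than one place, so this is the first step that isolates this position, and it is large. Nothing measured here explains the step. The compounds shown leave open how the step divides between the cyclopropyl ring and the carboxylic acid, and what an amide in place of that acid would give.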